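Chain unsaturation in two cores of a chromanone series

The source may hold more compounds than are shown below. What is called first, only, known or untested is meant among the compounds shown, and "the series" means these compounds.

Compound 1 `CCCC/C=C\CCCCCCCCCC1(O)CC(=O)c2c(O)cc(OCOC)cc2O1` gives 43200 nM in a functional assay on MCF7 cells (Homo sapiens) for antiproliferative activity, read by MTT assay; on this read-out lower numbers stand for stronger inhibition and higher numbers for weaker inhibition. Compound 2 `CCCCC/C=C\C/C=C\CCCCCCCC1(O)CC(=O)c2c(O)cc(OCOC)cc2O1` reaches only a limit of the assay, > 84100 nM. The change between them, (deca-1,4-dien-1-yl in place of oct-3-en-1-yl on a saturated chain carbon, seven bonds along the chain from a saturated ring carbon), made the step of an at least 1.9-fold higher number from compound 1 to compound 2 (0.28 log units; that floor lies within the scatter); it reads as a floor due to the limit of > 84100 nM in this assay, at which 1 of the 3 values shown sits. Compound 3 `CCCC/C=C\CCCCCCCCCc1cc(=O)c2c(O)cc(O)cc2o1` sits on a different core; the difference between the two cores is not broken down here. Among the compounds with values here, compound 3 gives 17500 nM, the lowest number so far. Compound 4 `CCCCC/C=C\C/C=C\CCCCCCCc1cc(=O)c2c(O)cc(O)cc2o1` carries the same kind of change, (deca-1,4-dien-1-yl in place of oct-3-en-1-yl on a saturated chain carbon, seven bonds along the chain from an aromatic carbon), though here the place is seven bonds along the chain from an aromatic carbon rather than from a saturated ring carbon. If the rise seen from compound 1 to compound 2 carries over, compound 4 is expected to move by a 2.0-fold higher number from compound 3 to compound 4 (0.30 log units; within the scatter), giving an estimated 35000 nM.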

Compound 4, half-maximal inhibitory concentration: 17500 nM
Compound 4: middle estimate off by 2.0-fold (0.30 log units), on the high side; the range from low to high includes it.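

In this assay, deca-1,4-dien-1-yl in place of oct-3-en-1-yl on the core of compound 3 gives no change at the digits printed from compound 3 to compound 4 (within the scatter). This shows that the change leaves no readable mark on that core, but it does not show that the change acts alike or differently on the two cores: the same change on two cores in this assay, an at least 1.9-fold higher number (0.28 log units; that floor lies within the scatter) from compound 1 to compound 2 and no change at the digits printed (within the scatter) from compound 3 to compound 4; the limit leaves it open whether they differ Compound 2 stands at a limit of the assay, so the step on the core of compound 1 is only a floor: the limit of > 84100 nM in this assay, at which 1 of the 4 values shown sits.

Open, from the compounds shown here alone, is whether a fully saturated chain, or a chain carrying an amine or a carboxylic acid, would read differently on either core. Also open, going by these compounds, is how far the step on the core of compound 1 really reaches.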